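The source may hold more compounds than are shown below. What is called first, only, known or untested is meant among the compounds shown, and "the series" means these compounds.

Measured compounds in a functional assay on PC-3 cells (Homo sapiens) for inhibition; a lower number here means a stronger inhibitor, a higher number a weaker inhibitor:

Compound 1 `Cc1c(C(=O)N/N=C\c2ccccc2F)oc2cccc(O)c12` gives the assay limit >= 40000 nM.
Compound 2 `Cc1c(C(=O)N/N=C\c2cccc(F)c2)oc2cccc(O)c12` gives the assay limit >= 40000 nM.
Compound 3 `Cc1c(C(=O)N/N=C\c2cccc(O)c2)oc2cccc(O)c12` gives 17600 nM.

Within the data shown here, compound 3 holds the only number in this assay; the two other values are limits, and the limit of >= 40000 nM in this assay, at which 2 of the 3 values shown sit, is where both of them sit. The steps into compound 3 are an at least 2.2-fold lower number from compound 1 to compound 3 (0.35 log units; beyond the scatter) and an at least 2.2-fold lower number from compound 2 to compound 3 (0.35 log units; beyond the scatter), each of them at least modest; the step that the two limits leave unreadable from compound 1 to compound 2 cannot be sized.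

Compound 4 `Cc1c(C(=O)N/N=C\c2ccccc2)oc2cccc(O)c12` differs from compound 3 by hydrogen in place of hydroxy on an aromatic carbon. The step that bears most directly on it is an at least 2.2-fold lower number from compound 2 to compound 3 (0.35 log units; beyond the scatter), where hydroxy entering in place of fluoro on that aromatic carbon gave the lower number. Taking the hydroxy away again is expected to undo that, so the step of a 2.0-fold higher number from compound 3 to compound 4 (0.30 log units; within the scatter) is expected to run towards a higher number, with a real chance that only a limit is reported. Compound 4 is therefore estimated at 35000 nM, within 12000 nM to 100000 nM.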

Compound 4, half-maximal inhibitory concentration: 29200 nM
The estimate for compound 4 lay 1.2-fold (0.08 log units) above the measured number; the range from low to high includes it.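

In this assay, among these compounds, the change from 3-hydroxyphenyl to phenyl gives the first step at this position with a number at both ends: a 1.7-fold higher number from compound 3 to compound 4 (0.22 log units; within the scatter). The hydroxy is therefore not shown to differ from hydrogen here, and the gain seen against the fluoro compounds does not establish a specific benefit of hydroxy. Against those fluoro compounds, the readings are an at least 1.3-fold lower number from compound 2 to compound 4 (0.13 log units; that floor lies within the scatter) and an at least 1.3-fold lower number from compound 1 to compound 4 (0.13 log units; that floor lies within the scatter), so neither fluoro placement is shown to differ from hydrogen, and the step between compound 1 and compound 2 cannot be read: the limit of >= 40000 nM in this assay, at which 2 of the 4 values shown sit.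

As far as these compounds go, whether an amine, a carboxylic acid or a methoxy group at this position would stand clearly apart from compound 3 and compound 4 remains open. From the compounds shown here alone, all four compounds share one core, so the effect of changes elsewhere on it also remains open.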